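The compounds below may be only part of what the source reports. "The series", "measured", "known", "first", "only" and "open" are said of these compounds alone.

Three compounds have been measured in a functional assay on HeLa cells (Homo sapiens); on this read-out lower numbers stand for stronger inhibition and higher numbers for weaker inhibition:

Compound 1, `Cc1ccc(C(=O)CC(SCC(=O)O)C(=O)O)cc1C`: 3810 nM
Compound 2, `CC(C)c1ccc(C(=O)CC(SCC(=O)O)C(=O)O)cc1`: 3330 nM
Compound 3, `Cc1ccc(C(=O)CC(SCC(=O)O)C(=O)O)c(Cl)c1`: 4730 nM

Compound 2 gives the lowest of the three numbers, yet the gaps to compound 1 and to compound 3 both lie within the scatter, so on these data the three compounds cannot be told apart. Among the compounds with values here, no pair of them differs in only one place, so no single step can be read from the measured set; they share a core and differ in the substitution of the aromatic ring.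

Compound 4, `O=C(O)CSC(CC(=O)c1ccc(Cl)cc1)C(=O)O`, has not yet been measured in this assay. It differs from compound 2 in one place: chloro in place of isopropyl on an aromatic carbon. Within the data shown here, nothing among the measured compounds shows how a chloro compares with an isopropyl at this place, so no step can be computed from them. Since compound 1, compound 2 and compound 3, with their different substitution of the ring, all fall within the scatter of one another, the expected step in this assay from compound 2 is small, most likely none beyond the scatter, leaning if anything towards a higher number. The estimated step is a 1.4-fold higher number from compound 2 to compound 4 (0.13 log units; within the scatter). Compound 4 is accordingly expected to give 4500 nM, with a range from 2000 nM to 10000 nM.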

Compound 4, half-maximal inhibitory concentration: 17300 nM
Beside the measured number, compound 4's estimate is 3.8-fold (0.58 log units) below it, and the stated range ends below it.
By their numbers in this assay, from the lowest: compounds 2, 1 and 3 (each within the scatter of the next); then compound 4.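

In this assay, within the data shown here, the place para to a large group turns out to matter: chloro in place of isopropyl on this aromatic carbon gives a 5.2-fold higher number from compound 2 to compound 4 (0.72 log units; beyond the scatter) and this is the first single change that can be read in the set. The step lies beyond the scatter, whereas the three earlier compounds, which differ from one another in more than one place, lie within the scatter of one another. Their closeness therefore did not mean that any group is tolerated at this place, at least not when chloro replaces isopropyl on an otherwise unsubstituted ring. No measurement at hand bears on why the step arises.

Going by these compounds, from this single pair, it remains open whether the step belongs to the loss of the isopropyl or to the arrival of the chloro, and whether it would persist on a ring carrying a second substituent. On these data alone, how an ethyl, a tert-butyl or a methoxy group at this place would compare with isopropyl and chloro also remains open, so no trend can yet be drawn along a series of groups.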